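A few compounds are considered here, and "the series" means these few. Any claim that something is new, unique, unknown or untested is made for them only; others in the source may bear on it.

Measured in a functional assay on HeLa cells (Homo sapiens) for inhibition, read by MTT assay, with a stated time of 24 h; a lower number here means a stronger inhibitor, a higher number a weaker inhibitor:
compound 1, `CCOC(=O)C1=Cc2ccccc2OC1(OCc1cc(-c2ccc(F)cc2F)no1)C(F)(F)F`: > 150000 nM, a limit of the assay
compound 2, `CCOC(=O)C1=Cc2ccccc2OC1(OCc1cn(CC(=O)Nc2cccc(Cl)c2)nn1)C(F)(F)F`: 12300 nM
compound 3, `O=C(O)C1=Cc2ccccc2OC1(OCc1cc(-c2ccc3ccccc3c2)no1)C(F)(F)F`: > 150000 nM, a limit of the assay

Among the measured compounds shown here, compound 2 stands alone as the only number given in this assay; the two other values are limits and not numbers. For compound 1 the reading in this assay is a limit. For compound 3 the reading in this assay is likewise a limit, so that two of the three shown values sit at the same limit (the limit of > 150000 nM in this assay, at which 2 of the 3 values shown sit). No pair of measured compounds differs in one place only, so no step between measured compounds can be counted, and nothing in the shown data says how a change on the amide-type nitrogen moves the read-out.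

Compound 4, `CCOC(=O)C1=Cc2ccccc2OC1(OCc1cn(CC(=O)Nc2ccccc2F)nn1)C(F)(F)F`, has not yet been measured. It differs from compound 2 in one place:

2-fluorophenyl in place of 3-chlorophenyl on an amide-type nitrogen

Both 3-chlorophenyl and 2-fluorophenyl sit on the amide-type nitrogen whose other neighbour is the carbonyl carbon; the rest of the structure is that of compound 2. With no measured step of this kind in the series, the expected step from compound 2 to compound 4 is a 1.2-fold higher number from compound 2 to compound 4 (0.09 log units; within the scatter), in no particular direction, and not expected to go beyond the usual scatter. Compound 4 is accordingly expected to give 15000 nM in this assay, with an estimated range from 5000 nM to 50000 nM.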

Compound 4, half-maximal inhibitory concentration: 49900 nM
Beside the measured number, compound 4's estimate is 3.3-fold (0.52 log units) below it; low and high end bracket the measured number.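

Notes on the amide-type nitrogen: in this assay, this position responds to the identity of the aryl group, since 2-fluorophenyl in place of 3-chlorophenyl gives a 4.1-fold higher number from compound 2 to compound 4 (0.61 log units; beyond the scatter), a modest loss of inhibition and the first step that can be read in the series. Among the compounds shown here, both groups keep the same heavy-atom count and the same six-membered aromatic ring of carbon, so the step comes from a swap of substituted phenyl groups alone, yet the single pair changes the halogen and its place on the phenyl together and cannot separate the two. Compound 4 still gives a number and not a limit, so the read-out remains measurable with this change, while the values that are limits stay as they were: the limit of > 150000 nM in this assay, at which 2 of the 4 values shown sit.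

Open is which of the two changes carries the step, a question that 2-chlorophenyl, 3-fluorophenyl or plain phenyl on the same nitrogen would address, and the compounds shown give no cause for it. Also open, on these data alone, is how a carboxylic acid in place of the ethyl ester, or a longer chain between the carbonyl and the triazole-bearing part, would behave with either aryl group.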